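This account rests on a few compounds, and the source may have more. Where it says the series, first, only, none or still open, it means among the compounds named here.

Measured so far:
compound 1 `COc1cc2c(Oc3ccc(NC(=O)N/N=C/c4ccc(Cl)cc4Cl)cc3F)ccnc2cc1OCCCN1CCCCC1` gives 460 nM in a functional assay on MKN-45 cells (Homo sapiens) for cytotoxicity, read by MTT assay, with a stated time of 72 h; a lower number here means a stronger inhibitor, a higher number a weaker inhibitor
compound 2 `COc1cc2c(Oc3ccc(NC(=O)N/N=C/c4ccc(OC(F)(F)F)cc4)cc3F)ccnc2cc1OCCCN1CCCCC1` gives 630 nM in this assay

Going by the values given here, compound 2 holds the higher of the two numbers, its only neighbour being compound 1 a 1.4-fold higher number from compound 1 to compound 2 (0.14 log units; within the scatter), a gap within the scatter.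

Compound 3 `COc1cc2c(Oc3ccc(NC(=O)N/N=C/c4ccc(N(C)C)cc4)cc3F)ccnc2cc1OCCCN1CCCCC1` differs from compound 2 by dimethylamino in place of trifluoromethoxy on an aromatic carbon. Among the compounds with values here, the one measured step that bears on a change of this aromatic substituent is a 1.4-fold higher number from compound 1 to compound 2 (0.14 log units; within the scatter), which stayed within the scatter. Within the data shown here, no measured step for dimethylamino exists. The step from compound 2 to compound 3 is therefore expected to be small, a 1.1-fold higher number from compound 2 to compound 3 (0.05 log units; within the scatter), with no direction claimed beyond the scatter. Compound 3 is estimated at 700 nM, range 250 nM to 2000 nM.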

Compound 3, half-maximal inhibitory concentration: 870 nM
Estimate against measurement, compound 3: 1.2-fold (0.09 log units) below, within the range that was stated.
By their numbers in this assay, from the lowest: compounds 1, 2 and 3 (each within the scatter of the next).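

In this assay, dimethylamino on the aromatic carbon para to a large group reads the same as trifluoromethoxy within the scatter (a 1.4-fold higher number from compound 2 to compound 3 (0.14 log units; within the scatter)). The widest pair also stays within the scatter (a 1.9-fold higher number from compound 1 to compound 3 (0.28 log units; within the scatter)), so 4-(dimethylamino)phenyl, 4-(trifluoromethoxy)phenyl and 2,4-dichlorophenyl are not separated at this position. No supporting measurement bears on this result.

The compounds shown leave open whether a carboxylic acid or a primary amine at this aromatic carbon would give a step beyond the scatter. As far as these compounds go, a longer chain in place of dimethylamino also remains open.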